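Removing One Fluorine from the Phenoxy Arm

The compounds below may be only part of what the source reports. "The series", "measured", "known", "first", "only" and "open" are said of these compounds alone.

The two measured compounds share one core and differ in the rings on the carbinol. Compound 1 `O=C(N1CCCCC1COc1ccc(F)cc1)n1ncc(C(O)(c2ccc(F)cc2)c2ccc(F)cc2)n1` carries 4-fluorophenyl groups there, and compound 2 `O=C(N1CCCCC1COc1ccc(F)cc1)n1ncc(C(O)(c2ccccc2)c2ccccc2)n1` carries phenyl groups. In an assay on isolated protein for inhibition of Monoacylglycerol lipase ABHD6 (Homo sapiens), read by fluorescence (a higher number here means a weaker inhibitor, a lower number a stronger inhibitor), compound 1 gives 200 nM, and compound 2 gives 251 nM. Compound 2 has the higher of the two numbers, yet its gap to compound 1 lies within the scatter, so the two cannot be told apart.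

Compound 3 `O=C(N1CCCCC1COc1ccccc1)n1ncc(C(O)(c2ccccc2)c2ccccc2)n1` is not yet measured. It differs from compound 2 in one place: hydrogen in place of fluoro on an aromatic carbon, para to a large group, so the 4-fluorophenoxy arm becomes a phenoxy arm. Within the data shown here, no pair of measured compounds shows what this swap does. Among the measured compounds shown here, the only guide is that the values of compound 1 and compound 2 sit within the scatter of each other. A small step from compound 2 to compound 3 is therefore expected, a 1.3-fold higher number from compound 2 to compound 3 (0.11 log units; within the scatter), not beyond the scatter. Compound 3 is expected to give 320 nM in this assay, within a range of 130 nM to 800 nM.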

Compound 3, half-maximal inhibitory concentration: 158 nM
The estimate for compound 3 lay 2.0-fold (0.31 log units) above the measured number, within the range that was stated.
By their numbers in this assay, from the lowest: compounds 3, 1 and 2 (each within the scatter of the next).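

In this assay, among these compounds, the change from 4-fluorophenoxy to phenoxy gives a 1.6-fold lower number from compound 2 to compound 3 (0.20 log units; within the scatter) and so provides the first direct reading of this swap at this position. The fluoro group on the phenoxy arm can therefore be replaced by hydrogen, at least with phenyl groups on the carbinol, without a difference that can be separated from ordinary assay noise; this rests on a single pair of compounds and sets no general rule. Nothing available explains this result.

From the compounds shown here alone, what a larger or differently built group would do at this same place on the ring remains open: a chloro group, a methoxy group or an amine could each give a clearer answer than a swap between fluoro and hydrogen. Going by these compounds, it is also open whether the same swap would read the same way with 4-fluorophenyl groups on the carbinol, and whether a longer chain between the piperidine-side carbon and the phenoxy oxygen would change the picture.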